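Amino in place of methoxy on the shared core

This account rests on a few compounds, and the source may have more. Where it says the series, first, only, none or still open, it means among the compounds named here.

compound 1 `Nc1ccccc1-c1ccc(O)cc1` gives 44.3 ug/mL
compound 2 `Oc1ccc(-c2cccc(O)c2)cc1` gives > 100 ug/mL, a limit of the assay
compound 3 `COc1cccc(-c2ccc(O)cc2)c1` gives 41 ug/mL

In a functional assay on MCF7 cells (Homo sapiens) for cytotoxicity, read by MTT assay, with a stated time of 3 days (a higher number here means a weaker inhibitor, a lower number a stronger inhibitor), compound 1 gives 44.3 ug/mL and compound 3 gives 41 ug/mL, two values within the scatter of each other. Compound 2 is reported only as a limit, > 100 ug/mL.

The next analogue, compound 4 `Nc1cccc(-c2ccc(O)cc2)c1`, has amino in place of methoxy on an aromatic carbon. For the measured compounds named here, one measured step bears on this place: an at least 2.4-fold lower number from compound 2 to compound 3 (0.38 log units; beyond the scatter), with methyl in place of hydrogen on an oxygen on an aromatic ring. Going by the values given here, that step shows that the group at this place can matter, but no measured step makes the exact change to amino. Among the compounds with values here, the only measured amino compound is compound 1, with its amino group at another place on the core, and its value of 44.3 ug/mL gives a reason to expect no large loss.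

What is expected in this assay is therefore a 1.2-fold higher number from compound 3 to compound 4 (0.09 log units; within the scatter), a change that stays within the scatter. For compound 4 the estimated value is 50 ug/mL, with an expected range of 22 ug/mL to 100 ug/mL.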

Compound 4, half-maximal inhibitory concentration: 6.5 ug/mL
For compound 4 the middle estimate is 7.7-fold (0.89 log units) above the measured one; measured number outside the range, below it.
By their numbers in this assay, from the lowest: compound 4; then compounds 3 and 1 (each within the scatter of the next). At a limit, above all of these: compound 2.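

In this assay, for the compounds shown here, the earlier compounds showed only that the group at this position can matter; amino in place of methoxy on an aromatic carbon gives a 6.3-fold lower number from compound 3 to compound 4 (0.80 log units; beyond the scatter), so a single change of group here moves the number well beyond the scatter. Amino in place of hydroxy on the same aromatic carbon gives an at least 15-fold lower number from compound 2 to compound 4 (1.18 log units; beyond the scatter). Compound 2 stands only as a limit, > 100 ug/mL, so this second step has a minimum size and no exact one: the limit of > 100 ug/mL in this assay, at which 1 of the 4 values shown sits.

Going by these compounds, whether the gain is specific to the free amino group stays open, and a methylamino, dimethylamino or acetamido group at this position would test that. Also open is whether methoxy, hydroxy and amino rank the same way at the place that carries the amino group in compound 1, where only one group is shown.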